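Adding a Methoxy Group to the Compound with the Lowest Number

This account rests on a few compounds, and the source may have more. Where it says the series, first, only, none or still open, it means among the compounds named here.

Measured so far:
Compound 1, `Cc1cccc2c1N(CC(=O)O)C/C(=C\c1ccc(F)cc1)C2=O`, gives 22.9% in an assay on HL-60 cells for inhibition of glutathione S-transferase P (Homo sapiens), read by spectrophotometry, tested at 20 uM; on this read-out higher numbers stand for more inhibition at the one concentration tested (going by the name of the read-out) and lower numbers for less inhibition.
Compound 2, `Cc1ccc2c(c1)C(=O)/C(=C/c1ccccc1)CN2CC(=O)O`, gives 4.23% in this assay.
Compound 3, `Cc1ccc(/C=C2\CN(CC(=O)O)c3c(C)cccc3C2=O)cc1`, gives 46.8% in this assay.

Compound 2 is the lowest of the three numbers; both other compounds stand beyond the scatter above it. Compound 4, `COc1ccc(/C=C2\CN(CC(=O)O)c3ccc(C)cc3C2=O)cc1`, has not yet been measured. It differs from compound 2 by methoxy in place of hydrogen on an aromatic carbon.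

Within the data shown here, only one step on the same phenyl ring has been measured: a number 23.9 percentage points higher from compound 1 to compound 3 (beyond the scatter). That step swapped one group for another rather than adding a group to a bare ring, so it does not show directly what a methoxy in place of hydrogen will do. It does show that a change on this ring can move the read-out by a modest amount, and the three values show that the unsubstituted phenyl of compound 2 sits lowest. A modest rise is therefore expected for compound 4, a number 11.8 percentage points higher from compound 2 to compound 4 (beyond the scatter), with wide uncertainty. Compound 4 is estimated at 16%, within 2% to 38%.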

Compound 4, a percentage reported as inhibition, at one concentration (the size of the read-out at that concentration, not a potency): 17.5%
Estimate against measurement, compound 4: 1.5 percentage points below; the measured number falls inside the stated range.
By their numbers in this assay, from the lowest: compound 2; then compounds 4 and 1 (each within the scatter of the next); then compound 3.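

Going from phenyl to 4-methoxyphenyl gives, in this assay, a number 13.3 percentage points higher from compound 2 to compound 4 (beyond the scatter), the first measured step that adds a group to a bare phenyl ring. The earlier step, a number 23.9 percentage points higher from compound 1 to compound 3 (beyond the scatter), exchanged one group for another, so it could not show whether this carbon accepts an added group at all. The new step shows that the hydrogen here can give way to methoxy without any loss on this read-out, and with a modest gain. Nothing measured here bears on why the number rises.

As far as these compounds go, what stays open is whether methoxy itself matters or whether other groups at this carbon, such as a hydroxyl, an amine or a longer ethoxy chain, would do the same. From the compounds shown here alone, it is also open whether methoxy would give a similar step on the core of compound 1.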